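Aryl piperazine swap on a T-type calcium channel series

A few compounds are considered here, and "the series" means these few. Any claim that something is new, unique, unknown or untested is made for them only; others in the source may bear on it.

Measured so far:
Compound 1 `CCCc1nc(-c2ccccc2)c(CNCCCN2CCN(c3cccc(F)c3)CC2)o1`: 68.9%
Compound 2 `CCCc1nc(-c2ccccc2)c(CNCCCN2CCN(c3cccc(Cl)c3)CC2)o1`: 65.9%

In an assay on HEK293 cells for inhibition of Voltage-dependent T-type calcium channel subunit alpha-1G (Homo sapiens), read by fluorescence, tested at 10 uM (on this read-out lower numbers stand for less inhibition and higher numbers for more inhibition at the one concentration tested (going by the name of the read-out)), compound 2 gives 65.9%, the lowest of the two numbers in hand; the nearest is compound 1, whose value lies within the scatter of it. For the measured compounds named here, the one measured step, a number 3 percentage points lower from compound 1 to compound 2 (within the scatter), changes only the halogen on the aromatic ring and itself stays within the scatter.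

Compound 3 `CCCc1nc(-c2ccccc2)c(CNCCCN2CCN(c3ccccc3C(F)(F)F)CC2)o1` is not yet measured. Relative to compound 2 the change is 2-(trifluoromethyl)phenyl in place of 3-chlorophenyl on an amine nitrogen in a ring. Going by the values given here, the measured step bears on this only loosely, since a whole new aromatic group enters rather than a halogen being exchanged; still, it is the only guide, and it showed no movement beyond the scatter. On that basis the expectation is a small change at most, with the downward tendency of the measured step carried over. For compound 3 the estimate is 62%, with a range from 45% to 78%, which is expected to mean a number 3.9 percentage points lower from compound 2 to compound 3 (within the scatter).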

Compound 3, a percentage reported as inhibition, at one concentration (the size of the read-out at that concentration, not a potency): 45%
Estimate against measurement, compound 3: 17 percentage points above; the measured number falls inside the stated range.
By their numbers in this assay, from the lowest: compound 3; then compounds 2 and 1 (each within the scatter of the next).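

In this assay the group on the amine nitrogen in the ring can clearly move the read-out: 2-(trifluoromethyl)phenyl in place of 3-chlorophenyl gives a number 20.9 percentage points lower from compound 2 to compound 3 (beyond the scatter) and in place of 3-fluorophenyl gives a number 23.9 percentage points lower from compound 1 to compound 3 (beyond the scatter) while the exchange of one halogen for the other stayed within the scatter. Both the substituent and its printed ring number change in these steps, so the compounds cannot separate the contribution of one from that of the other. Nothing available here accounts for the loss of inhibition.

Open, on these data alone, is whether 3-(trifluoromethyl)phenyl would stay with compound 1 and compound 2, or 2-chlorophenyl would fall with compound 3. Also open, as far as these compounds go, is how an unsubstituted phenyl or a methoxy group on that ring would read.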